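The compounds below may be only part of what the source reports. "The series", "measured", "known", "first", "only" and "open" are said of these compounds alone.

Measured compounds in an assay for binding affinity to 5-hydroxytryptamine receptor 1F (Homo sapiens), read by radioligand binding; on this read-out higher numbers stand for weaker inhibition and lower numbers for stronger inhibition:
compound 1 `O=C(Nc1ccc2[nH]cc(C3CCNCC3)c2n1)c1ccc(F)cc1` gives 9.5 nM;
compound 2 `CC(=O)Nc1ccc2[nH]cc(C3CCNCC3)c2n1` gives 45 nM.

Compound 2 stands at the higher of the two numbers in this assay. Going by the values given here, the one measured step, a 4.7-fold higher number from compound 1 to compound 2 (0.68 log units; beyond the scatter), swapped the whole acyl group. Compound 3 `CCC(=O)Nc1ccc2[nH]cc(C3CCNCC3)c2n1` differs from compound 2 by methyl in place of hydrogen on a saturated chain carbon bound to a carbonyl carbon, read one bond further out as acetyl to propanoyl. This is a far smaller change than the measured step, so only a faint trend toward larger acyl groups bears on it. In this assay compound 3 is expected to show a 1.3-fold lower number from compound 2 to compound 3 (0.11 log units; within the scatter), hardly beyond the scatter. Compound 3 is estimated at 35 nM, range 15 nM to 90 nM.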

Compound 3, inhibition constant: 35 nM
For compound 3 middle estimate and measured number coincide at the digits printed; measured number inside the range.
By their numbers in this assay, from the lowest: compound 1; then compounds 3 and 2 (each within the scatter of the next).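

In this assay, acetyl to propanoyl gives a 1.3-fold lower number from compound 2 to compound 3 (0.11 log units; within the scatter), so methyl in place of hydrogen on the saturated chain carbon bound to the carbonyl carbon does not separate these two amides. Ethyl in place of 4-fluorophenyl on the carbonyl carbon still gives a 3.7-fold higher number from compound 1 to compound 3 (0.57 log units; beyond the scatter), so the gap to compound 1 remains with ethyl as it did with methyl. No available evidence bears on either step. On these data alone, whether that gap follows chain length or requires the 4-fluorophenyl group stays open. A longer chain such as butanoyl, or benzoyl without the fluorine, would bear on this.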